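The source may report more compounds than this note shows. Statements on the series, on what has been measured and on what is new or still open speak of the compounds shown alone.

Values in a functional assay on HUVEC cells (Homo sapiens), read by scintillation counting and thymidine incorporation, with a stated time of 24 h (on this read-out lower numbers stand for stronger inhibition and higher numbers for weaker inhibition), so far:
compound 1 `CCC(C)n1ncn(-c2ccc(N3CCN(c4ccc(OC[C@@H]5CO[C@@](CC6CCCC6)(c6ccc(Cl)cc6Cl)O5)cc4)CC3)cc2)c1=O`: 512 nM
compound 2 `CCC(C)n1ncn(-c2ccc(N3CCN(c4ccc(OC[C@@H]5CO[C@@](Cc6ccccc6)(c6ccc(Cl)cc6Cl)O5)cc4)CC3)cc2)c1=O`: 513 nM
compound 3 `CCC(C)n1ncn(-c2ccc(N3CCN(c4ccc(OC[C@@H]5CO[C@@](Cn6ccnc6C)(c6ccc(Cl)cc6Cl)O5)cc4)CC3)cc2)c1=O`: 173 nM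

Compound 3 holds the lowest of these three numbers in this assay and stands ahead of both others beyond the scatter. Compound 4 `CCC(C)n1ncn(-c2ccc(N3CCN(c4ccc(OC[C@@H]5CO[C@@](Cn6cnc(C)c6)(c6ccc(Cl)cc6Cl)O5)cc4)CC3)cc2)c1=O` is not yet measured. It carries 4-methyl-1H-imidazol-1-yl in place of 2-methyl-1H-imidazol-1-yl on a saturated chain carbon bound to a saturated ring carbon in an otherwise unchanged structure. The measured steps at this place are a 3.0-fold lower number from compound 1 to compound 3 (0.47 log units; beyond the scatter) and a 3.0-fold lower number from compound 2 to compound 3 (0.47 log units; beyond the scatter), both modest, and a 1.0-fold higher number from compound 1 to compound 2 (0.00 log units; within the scatter), which stays within the scatter. Going by the values given here, no measured step compares 2-methyl-1H-imidazol-1-yl with 4-methyl-1H-imidazol-1-yl directly. A change smaller than those modest steps is therefore expected, within the scatter and leaning slightly towards weaker inhibition, with an estimated 1.3-fold higher number from compound 3 to compound 4 (0.10 log units; within the scatter) as the working figure. The expected value for compound 4 is 220 nM within an estimated range from 80 nM to 550 nM on this read-out.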

Compound 4, half-maximal inhibitory concentration: 102 nM
Estimate against measurement, compound 4: 2.2-fold (0.33 log units) above, within the range that was stated.
By their numbers in this assay, from the lowest: compounds 4 and 3 (each within the scatter of the next); then compounds 1 and 2 (each within the scatter of the next).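

In this assay the two methylimidazole isomers are not told apart at this place, with a 1.7-fold lower number from compound 3 to compound 4 (0.23 log units; within the scatter) as the step between 2-methyl-1H-imidazol-1-yl and 4-methyl-1H-imidazol-1-yl. The gain over the groups without ring nitrogen therefore does not rest on compound 3 alone: 4-methyl-1H-imidazol-1-yl gives a 5.0-fold lower number from compound 2 to compound 4 (0.70 log units; beyond the scatter) against phenyl and a 5.0-fold lower number from compound 1 to compound 4 (0.70 log units; beyond the scatter) against cyclopentyl. No available data explain these differences.
Still open, as far as these compounds go, is whether the methyl group matters at all, which unsubstituted 1H-imidazol-1-yl would test. Also open, from the compounds shown here alone, is whether a ring is needed on this saturated chain carbon, which a simple amine such as dimethylamino would test.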